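A few compounds are considered here, and "the series" means these few. Any claim that something is new, unique, unknown or untested is made for them only; others in the source may bear on it.

Compound 1, `COC1=C(C)C(=O)/C(=C(O)/C=C/c2ccc(OC)cc2)C(=O)C1(C)C`, is the reference point of the series. In a functional assay on HUVEC cells (Homo sapiens) (on this read-out lower numbers stand for an effect already at smaller amounts and higher numbers for an effect only at larger amounts of compound), compound 1 gives < 4 ug/mL, which is a limit of the assay and not a number. Compound 2, `COC1=C(C)C(=O)/C(=C(O)/C=C/c2ccc(F)cc2)C(=O)C1(C)C`, carries fluoro in place of methoxy on an aromatic carbon. In this assay compound 2 gives < 4 ug/mL, again a limit rather than a number. Compound 3, `COC1=C(C)C(=O)/C(=C(O)/C=C/c2cc(C)cc(C)c2)C(=O)C1(C)C`, carries 3,5-dimethylphenyl in place of 4-methoxyphenyl on a double-bonded chain carbon bound to a double-bonded chain carbon. In this assay compound 3 gives < 4 ug/mL, also a limit. The three measured steps, a step that the two limits leave unreadable from compound 1 to compound 2, a step that the two limits leave unreadable from compound 1 to compound 3 and a step that the two limits leave unreadable from compound 2 to compound 3, remain unreadable in size because of the limit of < 4 ug/mL in this assay, at which 3 of the 3 values shown sit. Where compound 1 stands on the scale can be fixed no closer than its limit.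

Compound 4, `C=Cc1ccccc1/C=C/C(O)=C1/C(=O)C(C)=C(OC)C(C)(C)C1=O`, is not yet measured. Its change from compound 1: 2-vinylphenyl in place of 4-methoxyphenyl on a double-bonded chain carbon bound to a double-bonded chain carbon. The nearest measured comparison, a step that the two limits leave unreadable from compound 1 to compound 3, also swaps the group at this place and gives no readable size. No step beyond the scatter is therefore expected for a step that the limit leaves unreadable from compound 1 to compound 4. Compound 4 is expected to sit at the same limit as its neighbours. In this assay compound 4 is estimated at 2 ug/mL, within 0.5 ug/mL to 8 ug/mL.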

Compound 4, concentration for half-maximal effect: < 1.1 ug/mL
Compound 4: a limit, no number; the forecaster's own chance of this, stated with the estimate: 60%; middle value at least 1.8-fold (0.25 log units) from the limit.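

In this assay compound 4 gives < 1.1 ug/mL, a limit of the assay and not a number. No size can be read for the steps to compound 4 from compound 1, compound 2 and compound 3, since all four values are limits. The compounds shown leave open whether the groups at this place differ at all in this read-out.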